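One Methoxy Step, Repeated on a Second Core

This account rests on a few compounds, and the source may have more. Where it says the series, first, only, none or still open, it means among the compounds named here.

Measured compounds:
- compound 1, `COc1cc(-c2cc(/C=C/C(=O)c3ccc(N)cc3)[nH]n2)cc(OC)c1OC`: 91%
- compound 2, `COc1ccc(C(=O)/C=C/c2cc(-c3cc(OC)c(OC)c(OC)c3)n[nH]2)cc1OC`: 94%
- compound 3, `COc1ccc(-c2cc(/C=C/C(=O)c3ccc(N)cc3)[nH]n2)cc1OC`: 97%

Of the compounds shown here, three have been tested in a functional assay on CCRF-CEM cells (Homo sapiens) for cytotoxicity, read by sulforhodamine B assay, with a stated time of 48 h, tested at 0.1 uM; a lower number here means a stronger effect, a higher number a weaker effect of the compound at the concentration tested. Compound 3 `COc1ccc(-c2cc(/C=C/C(=O)c3ccc(N)cc3)[nH]n2)cc1OC` gives 97%, compound 1 `COc1cc(-c2cc(/C=C/C(=O)c3ccc(N)cc3)[nH]n2)cc(OC)c1OC` gives 91%, and compound 2 `COc1ccc(C(=O)/C=C/c2cc(-c3cc(OC)c(OC)c(OC)c3)n[nH]2)cc1OC` gives 94%. All three numbers lie close together, and none of them can be called stronger or weaker than another.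

From compound 3 to compound 1 the change is methoxy in place of hydrogen on an aromatic carbon, and in this assay the step is a number 6 percentage points lower from compound 3 to compound 1 (within the scatter). How the core of compound 2 differs from that of compound 3 is not broken down here.

Compound 4 `COc1cc(C(=O)/C=C/c2cc(-c3cc(OC)c(OC)c(OC)c3)n[nH]2)cc(OC)c1OC` is not yet measured. It stands to compound 2 as compound 1 stands to compound 3: the change is methoxy in place of hydrogen on an aromatic carbon, the same change, occurring twice among these compounds. That expectation rests on compound 1, whose step a number 6 percentage points lower from compound 3 to compound 1 (within the scatter) was small. Compound 4 is therefore expected to show a number 4 percentage points lower from compound 2 to compound 4 (within the scatter) in this assay. For compound 4 the estimate is 90%, between 78% and 100%.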

Compound 4, a percentage reported as activity, at one concentration (the size of the read-out at that concentration, not a potency): 94%
The estimate for compound 4 lay 4 percentage points below the measured number, within the range that was stated.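

In this assay, the added methoxy gives no change at the digits printed from compound 2 to compound 4 (within the scatter), so this second instance of the change leaves the read-out where it was at the digits printed. All four numbers lie close together at this one concentration, so the result does not show that methoxy does anything of its own on either core, and it cannot say how the change would behave on a compound with a clearly stronger read-out. Set beside the earlier step, the change reads the same on both cores, which is agreement between two small steps and no more than that: the same change on two cores in this assay, a number 6 percentage points lower (within the scatter) from compound 3 to compound 1 and no change at the digits printed (within the scatter) from compound 2 to compound 4, 6 percentage points apart, within the scatter of two such steps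

The compounds shown leave open whether any other group at this aromatic carbon, such as hydroxy, fluoro or the longer ethoxy, would move the read-out beyond the scatter. They also leave open whether the two cores would still agree at a concentration where the compounds show a clear effect.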